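The source may report more compounds than this note shows. Statements on the series, on what has been measured and on what is new or still open speak of the compounds shown alone.

Of the compounds shown here, two have been measured in a functional assay (Sus scrofa) with sulfonylurea receptors; K-ATP channels (Homo sapiens) as the target; on this read-out higher numbers stand for an effect only at larger amounts of compound and lower numbers for an effect already at smaller amounts. Compound 1 `C/C=C/C(=O)Nc1c(C(O)(C(F)(F)F)C(F)(F)F)ccc2ccccc12` carries a prop-1-en-1-yl group on the carbonyl carbon of its amide; in this assay compound 1 gives 49 nM. Compound 2 `O=C(Nc1c(C(O)(C(F)(F)F)C(F)(F)F)ccc2ccccc12)c1cccc([N+](=O)[O-])c1` carries a 3-nitrophenyl group in the same place, and compound 2 gives 427 nM. Among the compounds with values here, the single measured step, an 8.7-fold higher number from compound 1 to compound 2 (0.94 log units; beyond the scatter), shows that exchanging the short open chain for the nitrated six-membered ring moved the number clearly upwards. Among the two compounds measured, compound 2 therefore stands at the higher end, with compound 1 as its only neighbour.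

Compound 3 `O=C(Nc1c(C(O)(C(F)(F)F)C(F)(F)F)ccc2ccccc12)c1ccco1` is not yet measured. It differs from compound 2 in one place: furan-2-yl in place of 3-nitrophenyl on a carbonyl carbon. Within the data shown here, only the step from compound 1 to compound 2 offers any guidance, and it describes a different exchange, so it bears on this one only loosely. The new group is a smaller aromatic ring without the nitro group, which makes a number between those of compound 1 and compound 2 seem plausible, but with wide uncertainty. The expected step is a 2.8-fold lower number from compound 2 to compound 3 (0.45 log units; beyond the scatter). Compound 3 is therefore estimated at 150 nM, within a range from 40 nM to 600 nM.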

Compound 3, half-maximal effective concentration: 182 nM
Estimate against measurement, compound 3: 1.2-fold (0.08 log units) below; the measured number falls inside the stated range.
By their numbers in this assay, from the lowest: compound 1; then compound 3; then compound 2.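

In this assay, the exchange of 3-nitrophenyl (9 heavy atoms) for furan-2-yl (5 heavy atoms) on the carbonyl carbon gives a 2.3-fold lower number from compound 2 to compound 3 (0.37 log units; beyond the scatter), so an aromatic ring at this place does not by itself fix the number as high as that of compound 2. The furan-2-yl ring does not match the open chain, however: the exchange of prop-1-en-1-yl for it gives a 3.7-fold higher number from compound 1 to compound 3 (0.57 log units; beyond the scatter), which leaves compound 1 with the lowest number of the three, with both of its steps beyond the usual scatter. No measured property of these groups is available to explain this order.

The compounds shown do not tell whether the higher number of compound 2 goes with its six-membered ring or with its nitro group, a question that a plain phenyl group on the same carbonyl carbon would address. They also leave open how a propyl chain, which has no double bond, would compare with the prop-1-en-1-yl group of compound 1.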